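A few compounds are considered here, and "the series" means these few. Any claim that something is new, unique, unknown or untested is made for them only; others in the source may bear on it.

Measured compounds:
compound 1 `N#Cc1ccc(Nc2nccc(OCc3ccc(Cl)cc3)n2)cc1` — 156000 nM
compound 2 `Cc1cccc(COc2ccnc(Nc3ccc(C#N)cc3)n2)c1` — 30000 nM

Among the measured compounds shown here, in an ADME assay on MT4 cells (Homo sapiens) for cytotoxicity, read by MTT assay, with a stated time of 5 days (a higher number here means that more compound is tolerated, a lower number that less compound is tolerated), compound 2 gives the lower of the two numbers, and its nearest neighbour is compound 1, which is separated by the one recorded step. For the measured compounds named here, that step, a 5.2-fold lower number from compound 1 to compound 2 (0.72 log units; beyond the scatter), is the only measured change in this small set.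

Compound 3 `N#Cc1ccc(Nc2nccc(OCc3cccc(C#N)c3)n2)cc1` has not been measured. It differs from compound 2 as follows: cyano in place of methyl on an aromatic carbon. Going by the values given here, no measured step concerns a cyano in place of a methyl, so the recorded step from compound 1 to compound 2 bears on it only loosely, as a sign that swapping the substituent on that phenyl can move the number by a modest amount. With nothing closer to draw on, the expected step is a 1.7-fold higher number from compound 2 to compound 3 (0.22 log units; within the scatter), leaning toward a somewhat higher number but possibly within the scatter. For compound 3 the estimate in this assay is 50000 nM, with a range from 15000 nM to 150000 nM.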

Compound 3, half-maximal cytotoxic concentration: 4100 nM
The estimate for compound 3 lay 12-fold (1.09 log units) above the measured number; the whole stated range lies above it.
By their numbers in this assay, from the lowest: compound 3; then compound 2; then compound 1.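

In this assay, cyano in place of methyl on an aromatic carbon of this phenyl ring gives a 7.3-fold lower number from compound 2 to compound 3 (0.86 log units; beyond the scatter), so a substituent kept at the same place on the ring still moves the number beyond the scatter when only the group changes. Set against the 4-chlorophenyl group, the 3-cyanophenyl group gives a 38-fold lower number from compound 1 to compound 3 (1.58 log units; beyond the scatter), the only step in this set recorded as large. No measurement at hand accounts for the drop.

Compound 1 differs from the other two in both the group and its place on the ring, so the contribution of each stays unseparated. As far as these compounds go, how an amine, a carboxylic acid or a methoxy group at this aromatic carbon would read remains open.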